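A few compounds are considered here, and "the series" means these few. Any claim that something is new, unique, unknown or untested is made for them only; others in the source may bear on it.

Working notes on the series. Among the measured compounds shown here, compound 2 `Nc1cc(N)c2nc(-c3ccccc3)c(NCc3ccc(F)cc3)nc2c1` is the reference point: in a functional assay on SK-OV-3 cells (Homo sapiens) for inhibition, read by sulforhodamine B assay, with a stated time of 48 h (a higher number here means that more compound is tolerated, a lower number that less compound is tolerated), compound 2 gives 53700 nM, the only plain number among the three measured values. Compound 1 `Nc1cc(N)c2nc(-c3ccccc3)c(Oc3ccc(Cl)c(Cl)c3)nc2c1` stops at a limit of the assay; in this assay compound 1 gives < 100000 nM. Compound 3 `COc1ccc(CNc2nc3cc(N)cc(N)c3nc2-c2ccccc2)cc1` stops at a limit as well; in this assay compound 3 gives < 100000 nM. The two measured steps therefore carry no readable size: a step that the limit leaves unreadable from compound 1 to compound 2 and a step that the limit leaves unreadable from compound 2 to compound 3, which follows from the limit of < 100000 nM in this assay, at which 2 of the 3 values shown sit.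

Compound 4 `COc1ccc(Sc2nc3cc(N)cc(N)c3nc2-c2ccccc2)cc1` has not been measured. Its change from compound 2 is (4-methoxyphenyl)sulfanyl in place of (4-fluorobenzyl)amino on an aromatic carbon. Neither measured step bears on this change with a readable size, so no direction can be taken from them, and the expectation for compound 4 has to start from where compound 2 stands. The step expected for compound 4 in this assay is a 1.1-fold lower number from compound 2 to compound 4 (0.03 log units; within the scatter), which is not beyond the usual scatter. The estimate for compound 4 is 50000 nM, within 15000 nM to 100000 nM. A real chance remains that compound 4 is returned only as a limit, as two of the three measured values were.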

Compound 4, concentration lethal to 50% of the cells: < 100000 nM
Compound 4 was reported as a limit; the forecaster's own chance of this, stated with the estimate: 40%; the middle value is on the limit's open side.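

In this assay compound 4 gives < 100000 nM, which is a limit of the assay and not a number. The steps from compound 2 and from compound 1 to compound 4 therefore cannot be read: the limit of < 100000 nM in this assay, at which 3 of the 4 values shown sit. Left open is whether compound 1, compound 3 and compound 4 differ from compound 2 or from one another at all.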